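Isopropoxy in place of chloro: one step still open

This account rests on a few compounds, and the source may have more. Where it says the series, first, only, none or still open, it means among the compounds named here.

compound 1 `COc1ccc(-c2cc(NNC(=O)Nc3cc(Cl)nc(Cl)c3)nc3c2cnn3C)cc1` gives 12300 nM
compound 2 `Cc1c(Cc2ccccc2)c(NNC(=O)Nc2cc(Cl)nc(Cl)c2)nc2c1cnn2C` gives 13600 nM

In a functional assay on HCT-116 cells (Homo sapiens) for cytotoxicity, read by MTT assay, with a stated time of 48 h, in the presence of a further agent that is not named here (on this read-out lower numbers stand for an effect already at smaller amounts and higher numbers for an effect only at larger amounts of compound), compound 1 stands level with compound 2, and the gap between them lies within the scatter of repeated measurements. Those two values are all that is known so far. Compound 3 `COc1ccc(-c2cc(NNC(=O)Nc3cc(Cl)nc(OC(C)C)c3)nc3c2cnn3C)cc1` keeps the core of compound 1 but carries isopropoxy in place of chloro on an aromatic carbon, next to the ring nitrogen (isopropoxy in place of chloro on an aromatic carbon). The group thus changes from 2,6-dichloropyridin-4-yl to 2-chloro-6-isopropoxypyridin-4-yl. For the measured compounds named here, no measured pair shows a change of this kind, so no direction is favoured, and in this assay no step beyond the scatter is expected. The estimated change is a 1.0-fold lower number from compound 1 to compound 3 (0.01 log units; within the scatter), though the uncertainty is wide. Compound 3 is expected at 12000 nM, with an estimated range from 4000 nM to 36000 nM.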

Compound 3, half-maximal effective concentration: 39800 nM
Compound 3: middle estimate off by 3.3-fold (0.52 log units), on the low side, and the stated range ends below it.
By their numbers in this assay, from the lowest: compounds 1 and 2 (each within the scatter of the next); then compound 3.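

In this assay, for the compounds shown here, the first step that can be read at this position shows that it is not indifferent to change: isopropoxy in place of chloro, on an aromatic carbon next to the ring nitrogen, gives a 3.2-fold higher number from compound 1 to compound 3 (0.51 log units; beyond the scatter). Going by these compounds alone, compounds 1 and 2 could not show this, as both carry the 2,6-dichloropyridin-4-yl group, and the move to 2-chloro-6-isopropoxypyridin-4-yl is the only change of this group seen so far. Nothing available explains why the number rises with this change.

The compounds shown leave open whether a methoxy group or an amine at this place would shift the number as isopropoxy does, and whether the same change on the core of compound 2 would give a similar step. Also open, going by these compounds, is what happens when the remaining chloro group gives way to a hydrogen or a second isopropoxy.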